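Swapping the amide aryl group: compound 3 to compound 4

The source may hold more compounds than are shown below. What is called first, only, known or untested is meant among the compounds shown, and "the series" means these compounds.

Measured compounds:
- compound 1, `COc1ccc2c(=O)c(/C=C/C(=O)Nc3ccc(C)cc3)coc2c1`: 39300 nM
- compound 2, `Cc1ccccc1NC(=O)/C=C/c1coc2cc(O)ccc2c1=O`: 9320 nM
- compound 3, `CCOc1ccc(NC(=O)/C=C/c2coc3cc(OC)ccc3c2=O)cc1`: > 100000 nM

These three share one core and differ in the group on the amide nitrogen and in a substituent on the core. For the measured compounds named here, in a functional assay (QGY7701 cells, Homo sapiens) for inhibition, read by MTT assay, with a stated time of 48 h (a higher number here means a weaker inhibitor, a lower number a stronger inhibitor), compound 3 gives only a limit, (the limit of > 100000 nM in this assay, at which 1 of the 3 values shown sits), so no exact number is known for it; it is the one compound of the three for which this is so.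

Compound 4, `COc1ccc2c(=O)c(/C=C/C(=O)Nc3ccccc3C)coc2c1`, has not been measured. It differs from compound 3 by 2-methylphenyl in place of 4-ethoxyphenyl on an amide-type nitrogen.

Going by the values given here, one measured step bears on this change. The step of an at least 2.5-fold higher number from compound 1 to compound 3 (0.40 log units; beyond the scatter) went from methyl to ethoxy on that aromatic ring and weakened inhibition at least modestly. The change to compound 4 removes the ethoxy again and puts a methyl group back on the ring, now as 2-methylphenyl, so a fall in the number, back toward the neighbourhood of compound 1 or lower, is expected. Compound 2, which also carries 2-methylphenyl, gives 9320 nM in this assay, but its core differs as well, so it guides only loosely.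

Compound 4 is therefore estimated at 25000 nM, within 8000 nM to 90000 nM, a step of an at least 4.0-fold lower number from compound 3 to compound 4 (0.60 log units; beyond the scatter).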

Compound 4, half-maximal inhibitory concentration: 22500 nM
Estimate against measurement, compound 4: 1.1-fold (0.05 log units) above; the measured number falls inside the stated range.
By their numbers in this assay, from the lowest: compound 2; then compounds 4 and 1 (each within the scatter of the next). At a limit, above all of these: compound 3.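

In this assay, 2-methylphenyl in place of 4-ethoxyphenyl on the amide-type nitrogen gives an at least 4.4-fold lower number from compound 3 to compound 4 (0.64 log units; beyond the scatter), and that size is only a bound, since the starting value is a limit and not a number: the limit of > 100000 nM in this assay, at which 1 of the 4 values shown sits.

Moving the methyl group, with 2-methylphenyl in place of 4-methylphenyl at the same nitrogen, gives a 1.7-fold lower number from compound 1 to compound 4 (0.24 log units; within the scatter), so these two methyl-bearing groups cannot be told apart here, and the large step seen on leaving 4-ethoxyphenyl does not depend on where the methyl sits. With 2-methylphenyl held fixed, methyl in place of hydrogen on the oxygen on the aromatic ring of the core gives a 2.4-fold higher number from compound 2 to compound 4 (0.38 log units; beyond the scatter), a modest change that can now be read apart from any change in the amide aryl group.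

From the compounds shown here alone, it remains open whether that change on the oxygen has the same size when the amide carries 4-methylphenyl or 4-ethoxyphenyl. Going by these compounds, it also remains open how this assay responds to a plain phenyl group, to an amine or a carboxylic acid on that ring, or to a chain longer than ethoxy.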